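The compounds below may be only part of what the source reports. "The series", "measured", "known", "first", "only" and "open" are said of these compounds alone.

Compound 3 `CNC(=O)NCc1nc(-c2ccc(OC)cc2)c(-c2ccc(OC)cc2)s1` shares its core with compound 1 `COc1ccc(-c2nc(CNC(=O)CSc3ccccc3)sc2-c2ccc(OC)cc2)cc1` and compound 2 `COc1ccc(-c2nc(CNC(=O)C3=NNC(=O)CC3)sc2-c2ccc(OC)cc2)cc1`. In a functional assay with Oryctolagus cuniculus as the target (a higher number here means a weaker inhibitor, a lower number a stronger inhibitor), compound 3 gives 22 nM, the lowest of the two numbers shown. Compound 2 gives 55 nM in this assay, and the step of a 2.5-fold lower number from compound 2 to compound 3 (0.40 log units; beyond the scatter) separates the two. Compound 1 in this assay gives < 100 nM, which is a limit of the assay and not a number (the limit of < 100 nM in this assay, at which 1 of the 3 values shown sits); the steps a step that the limit leaves unreadable from compound 1 to compound 2 and a step that the limit leaves unreadable from compound 1 to compound 3 therefore stay unreadable. Compound 4 `COc1ccc(-c2nc(C3=NNC(=O)CC3)sc2-c2ccc(OC)cc2)cc1` has not been measured. It differs from compound 3 in one place: a group of 7 heavy atoms (4 carbon, 2 nitrogen, 1 oxygen; one six-membered non-aromatic ring with 2 hetero atoms) in place of a group of 6 heavy atoms (3 carbon, 2 nitrogen, 1 oxygen; no ring), on an aromatic carbon. Within the data shown here, the single readable step, a 2.5-fold lower number from compound 2 to compound 3 (0.40 log units; beyond the scatter), took the same six-membered non-aromatic ring out and brought methylamino in, on a carbonyl carbon; compound 4 brings that ring back, now on the aromatic carbon rather than on a carbonyl carbon. The change is expected to undo part of that gain, a step of a 2.3-fold higher number from compound 3 to compound 4 (0.36 log units; beyond the scatter). Compound 4 is estimated to give 50 nM in this assay, within a range from 20 nM to 150 nM.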

Compound 4, half-maximal inhibitory concentration: > 1000 nM
Compound 4 was reported as a limit (the forecaster's own chance of this, stated with the estimate: 10%); middle value at least 20-fold (1.30 log units) from the limit.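

Up to this point, the readable change had been made on a carbonyl carbon, with the chain to the aromatic carbon left in place; here the whole ((methylcarbamoyl)amino)methyl group leaves, and the ring stands directly on the aromatic carbon next to the ring nitrogen and the ring sulfur. In this assay this gives an at least 45-fold higher number from compound 3 to compound 4 (1.65 log units; beyond the scatter), so this position responds far more strongly to this change than the earlier readable step suggested. The value of compound 4 is a limit of the assay and not a number: the limit of > 1000 nM in this assay, at which 1 of the 4 values shown sits.

The compounds shown leave open which part of the departing group matters, and how much of the step belongs to the ring itself. An aminomethyl group or a plain methyl on the same aromatic carbon would begin to separate these.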